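From a benzyloxy to an amino group

The source may hold more compounds than are shown below. What is called first, only, known or untested is meant among the compounds shown, and "the series" means these compounds.

In a functional assay on blood (Homo sapiens), with a stated time of 60 min, in the presence of a further agent that is not named here (a lower number here means that less compound is needed, a higher number that more compound is needed for the effect), compound 1 `O=C(O)C1(S(=O)(=O)c2ccc(Oc3ccc(OC(F)(F)F)cc3)cc2)CCC2(CCNCC2)C1` gives 1800 nM. Compound 2 `COC(=O)C1(S(=O)(=O)c2ccc(Oc3ccc(OC(F)(F)F)cc3)cc2)CCC2(CCNCC2)C1` gives > 15000 nM, which is a limit of the assay and not a number. Compound 3 `O=C(OCc1ccccc1)C1(S(=O)(=O)c2ccc(Oc3ccc(OC(F)(F)F)cc3)cc2)CCC2(CCNCC2)C1` gives > 15000 nM, also only a limit. Compound 4 `NC(=O)C1(S(=O)(=O)c2ccc(Oc3ccc(OC(F)(F)F)cc3)cc2)CCC2(CCNCC2)C1` differs from compound 3 by amino in place of benzyloxy on a carbonyl carbon. Among the measured compounds shown here, two measured steps bear on this change. Capping the oxygen of compound 1 with methyl gave an at least 8.3-fold higher number from compound 1 to compound 2 (0.92 log units; beyond the scatter), and capping it with benzyl gave an at least 8.3-fold higher number from compound 1 to compound 3 (0.92 log units; beyond the scatter), both beyond the scatter. Compound 4 also lacks the hydrogen on that oxygen, so a high number is expected. The expected step is a number no higher from compound 3 to compound 4 (the limit leaves the size open). In this assay, the estimate for compound 4 is 15000 nM, with an expected range from 5000 nM to 40000 nM.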

Compound 4, half-maximal effective concentration: 3700 nM
Beside the measured number, compound 4's estimate is 4.1-fold (0.61 log units) above it; measured number below the stated range.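

In this assay, among the compounds shown here, the hydroxy on this carbonyl carbon is not the only group that gives a readable number, as amino in its place gives an at least 4.0-fold lower number from compound 3 to compound 4 (0.60 log units; beyond the scatter) and also an at least 4.0-fold lower number from compound 2 to compound 4 (0.60 log units; beyond the scatter). Set against hydroxy itself, amino gives a 2.1-fold higher number from compound 1 to compound 4 (0.31 log units; beyond the scatter), a modest step. The two steps from the esters give only a minimum size, as their starting values are limits and not numbers: the limit of > 15000 nM in this assay, at which 2 of the 4 values shown sit.

The compounds shown leave open how a methylamino or a dimethylamino group would fare on this carbonyl carbon.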